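Swapping Phenyl for Allyl on the Shared Core

The compounds below may be only part of what the source reports. "The series", "measured", "known", "first", "only" and "open" are said of these compounds alone.

Measured so far:
compound 1, `COc1ccc(-c2nnc(SCC(=O)Nc3ccc(/C(C)=N/O)cc3)n2-c2ccccc2)cc1OC`, 77%
compound 2, `C=CCn1c(SCC(=O)Nc2ccc(/C(C)=N/O)cc2)nnc1-c1ccc(OC)c(OC)c1`, 70%
compound 3, `COc1cc(-c2nnc(SCC(=O)Nc3ccc(C(C)=O)cc3)n2-c2ccccc2)cc(OC)c1OC`, 55%

These three compounds were tested in a functional assay on the whole organism (strain albino) for inhibition, with Rattus norvegicus as the target, read by paw edema, with stated times of 30 min and 3 h, at a dose of 0.28 mmol/kg by the oral route; on this read-out lower numbers stand for less inhibition and higher numbers for more inhibition at the one dose given (going by the name of the read-out). In this assay compound 1 gives 77% and compound 2 gives 70%; the step of a number 7 percentage points lower from compound 1 to compound 2 (within the scatter) comes from a single change, (allyl in place of phenyl on an aromatic nitrogen). Compound 3 gives 55%, the lowest of the three, and its gaps to compound 1 and compound 2 lie beyond the usual scatter. How the core of compound 3 differs from that of compound 1 is not broken down here.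

Compound 4, `C=CCn1c(SCC(=O)Nc2ccc(C(C)=O)cc2)nnc1-c1cc(OC)c(OC)c(OC)c1`, has not yet been measured. It differs from compound 3 by allyl in place of phenyl on an aromatic nitrogen, the same kind of change as from compound 1 to compound 2, though here the place is next to the ring atom that bears a 3,4,5-trimethoxyphenyl group, where compound 1 carries a 3,4-dimethoxyphenyl group. Because the earlier step of a number 7 percentage points lower from compound 1 to compound 2 (within the scatter) stayed within the scatter, a similarly small step is expected for compound 4, namely a number 5 percentage points lower from compound 3 to compound 4 (within the scatter). Compound 4 is thus estimated at 50%, expected to fall between 38% and 62%.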

Compound 4, a percentage reported as inhibition, in the whole organism at one dose (the size of the read-out at that dose, not a potency): 55%
Compound 4: the middle estimate sits 5 percentage points below what was measured; low and high end bracket the measured number.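

In this assay, putting allyl in place of phenyl on an aromatic nitrogen of the core of compound 3 gives no change at the digits printed from compound 3 to compound 4 (within the scatter), so on this second core too the swap stays within the usual scatter. Set side by side, the two steps cannot be told apart: the same change on two cores in this assay, a number 7 percentage points lower (within the scatter) from compound 1 to compound 2 and no change at the digits printed (within the scatter) from compound 3 to compound 4, 7 percentage points apart, within the scatter of two such steps. Within these two pairs, then, phenyl and allyl on this nitrogen give readings that cannot be separated at the one dose tested, but two pairs do not show that the same would hold on any other core, and a percentage at one dose is not a potency.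

The compounds shown leave open what other groups on that nitrogen would do, such as a methyl, a longer chain like butyl, or a chain ending in an amine. Among the compounds shown here, they also leave open what the 3,4,5-trimethoxyphenyl group contributes on its own, as no pair here differs in that place alone.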